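One Added Fluoro on Compound 1

The compounds below may be only part of what the source reports. "The series", "measured", "known", "first", "only" and "open" are said of these compounds alone.

Values in a functional assay on PC-3 cells (Homo sapiens) for cytotoxicity, read by MTT assay, with a stated time of 72 h; on this read-out higher numbers stand for weaker inhibition and lower numbers for stronger inhibition:
- compound 1 `Cc1cc(=O)n(-c2ccc(Br)cc2F)nc1C(=O)Nc1ccc(Oc2ncnc3c2ccn3C)cc1`: 18800 nM
- compound 2 `Cc1cc(=O)n(-c2cccc(F)c2)nc1C(=O)Nc1ccc(Oc2ncnc3c2ccn3C)cc1`: > 60000 nM, a limit
- compound 3 `Cc1ccc(-n2nc(C(=O)Nc3ccc(Oc4ncnc5c4ccn5C)cc3)c(C)cc2=O)cc1`: > 60000 nM, a limit

Only compound 1 has an actual number. The other two values mark (the limit of > 60000 nM in this assay, at which 2 of the 3 values shown sit).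

Compound 4 `Cc1cc(=O)n(-c2ccc(Br)cc2F)nc1C(=O)Nc1ccc(Oc2ncnc3c2ccn3C)c(F)c1` differs from compound 1 by one change: fluoro in place of hydrogen on an aromatic carbon. The measured steps, an at least 3.1-fold higher number from compound 1 to compound 2 (0.50 log units; beyond the scatter) and an at least 3.1-fold higher number from compound 1 to compound 3 (0.50 log units; beyond the scatter), both replace the group on an aromatic nitrogen, so neither gives a size for a change on this aromatic carbon. With no direct guide, no step beyond the scatter is expected in this assay. The expected change is a 1.3-fold lower number from compound 1 to compound 4 (0.10 log units; within the scatter). Compound 4 is estimated at 15000 nM, with an expected range from 5000 nM to 50000 nM.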

Compound 4, half-maximal inhibitory concentration: 6670 nM
For compound 4 the middle estimate is 2.2-fold (0.35 log units) above the measured one, within the range that was stated.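

In this assay, for the compounds shown here, fluoro in place of hydrogen on an aromatic carbon gives a 2.8-fold lower number from compound 1 to compound 4 (0.45 log units; beyond the scatter) and so shows that this six-membered aromatic ring of carbon only can also shift the read-out, while the earlier steps changed only the group on an aromatic nitrogen. Nothing shown here gives a reason for this step.

As far as these compounds go, whether chloro, methoxy or an amine on this same carbon would move the number in the same direction stays open. So does whether fluoro here gives a similar step when the group on the aromatic nitrogen differs.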